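Bis(trifluoromethyl)benzenesulfonamide series: benzylamine variation

The source may hold more compounds than are shown below. What is called first, only, known or untested is meant among the compounds shown, and "the series" means these compounds.

Measured so far:
- compound 1, `COc1ccc(CNCCCNS(=O)(=O)c2cc(C(F)(F)F)cc(C(F)(F)F)c2)cc1OC`, in a functional assay on A2780 cells (Homo sapiens) for inhibition, read by MTT assay, with a stated time of 72 h (a lower number here means a stronger inhibitor of growth, a higher number a weaker inhibitor of growth), compound 1 gives 3800 nM
- compound 2, `O=S(=O)(NCCCNCc1cccc(Cl)c1)c1cc(C(F)(F)F)cc(C(F)(F)F)c1`, compound 2 gives 2200 nM
- compound 3, `COc1cccc(CNCCCNS(=O)(=O)c2cc(C(F)(F)F)cc(C(F)(F)F)c2)c1`, compound 3 gives 1600 nM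

Going by the values given here, compound 1 stands at the highest number of the three; the gap to compound 2 is within the scatter, and a 2.4-fold lower number from compound 1 to compound 3 (0.38 log units; beyond the scatter) is the only step beyond it. Compound 4, `O=S(=O)(NCCCNCc1ccc(Cl)cc1)c1cc(C(F)(F)F)cc(C(F)(F)F)c1`, is not yet measured. It differs from compound 1 by 4-chlorophenyl in place of 3,4-dimethoxyphenyl on a saturated chain carbon bound to an amine nitrogen.

The closest measured step is a 1.7-fold lower number from compound 1 to compound 2 (0.24 log units; within the scatter), within the scatter; a 1.4-fold lower number from compound 2 to compound 3 (0.14 log units; within the scatter) is likewise within it. A chlorophenyl replacing the dimethoxyphenyl has so far given no change beyond the scatter. For compound 4 the expected step is therefore a 1.5-fold lower number from compound 1 to compound 4 (0.18 log units; within the scatter), a small decrease if any. The estimate for compound 4 is 2500 nM, with a range of 1200 nM to 5500 nM.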

Compound 4, concentration for 50% growth inhibition: 1800 nM
Compound 4: the middle estimate sits 1.4-fold (0.14 log units) above what was measured; measured number inside the range.
By their numbers in this assay, from the lowest: compounds 3, 4, 2 and 1 (each within the scatter of the next, the first and the last beyond it).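

Replacing 3,4-dimethoxyphenyl with 4-chlorophenyl gives a 2.1-fold lower number from compound 1 to compound 4 (0.32 log units; beyond the scatter) as a modest step beyond the scatter, which the 3-chlorophenyl of compound 2 did not reach. Within the scatter, this place does not separate 4-chlorophenyl from 3-methoxyphenyl (a 1.1-fold higher number from compound 3 to compound 4 (0.05 log units; within the scatter)) or from 3-chlorophenyl (a 1.2-fold lower number from compound 2 to compound 4 (0.09 log units; within the scatter)). No measurement on hand explains these numbers.

Still open, on these data alone, is whether an unsubstituted phenyl or a nitrile-bearing phenyl at this place would stay within the same narrow band. As far as these compounds go, the effect of a longer chain on the shared core also remains unknown.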